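The source may report more compounds than this note shows. Statements on the series, on what has been measured and on what is new or still open speak of the compounds shown alone.

Measured in a functional assay (blood) for inhibition, with Homo sapiens as the target; on this read-out lower numbers stand for stronger inhibition and higher numbers for weaker inhibition:
- Compound 1 `CCCC(Oc1ccc2c(c1)c(SC(C)(C)C)c(CC(C)(C)C(=O)O)n2Cc1ccc(Cl)cc1)c1ccc2ccccc2n1`: > 3000 nM (a limit of the assay, not a number)
- Compound 2 `CC(C)(C)Sc1c(CC(C)(C)C(=O)O)n(Cc2ccc(Cl)cc2)c2ccc(OCc3ccc4cnccc4n3)cc12`: 980 nM
- Compound 3 `CC(C)(C)Sc1c(CC(C)(C)C(=O)O)n(Cc2ccc(Cl)cc2)c2ccc(OCc3nc4ccccc4s3)cc12`: 260 nM

Of the two actual numbers, compound 2 holds the higher one, so it is the weaker of that pair. Compound 4 `CC(COc1ccc2c(c1)c(SC(C)(C)C)c(CC(C)(C)C(=O)O)n2Cc1ccc(Cl)cc1)c1ccccn1` is still unmeasured. Its change from compound 2 is this: a group of 8 heavy atoms (7 carbon, 1 nitrogen; one six-membered aromatic ring with 1 hetero atom) in place of a group of 10 heavy atoms (8 carbon, 2 nitrogen; 2 six-membered aromatic rings with 1 hetero atom each), on a saturated chain carbon bound to an oxygen on an aromatic ring. The entering group is 1-(pyridin-2-yl)ethyl, with one aromatic ring in place of two.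

For the measured compounds named here, the only measured step at this place, a 3.8-fold lower number from compound 2 to compound 3 (0.58 log units; beyond the scatter), was modest but beyond the scatter. Both groups in that step carry two rings, so it gives only a rough guide to size, and none to the effect of losing a ring. A modest move toward weaker inhibition in this assay is therefore expected, held with little confidence. The expected step is a 2.0-fold higher number from compound 2 to compound 4 (0.31 log units; beyond the scatter). For compound 4 the estimated value is 2000 nM, with an expected range from 700 nM to 6000 nM.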

Compound 4, half-maximal inhibitory concentration: 270 nM
Compound 4: middle estimate off by 7.4-fold (0.87 log units), on the high side, outside the stated range (below it).
By their numbers in this assay, from the lowest: compounds 3 and 4 (each within the scatter of the next); then compound 2. At a limit, above all of these: compound 1.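

In this assay, the second aromatic ring of compound 2 turns out not to be required at this place on the saturated chain carbon: 1-(pyridin-2-yl)ethyl, with one aromatic ring, gives a stronger result (a 3.6-fold lower number from compound 2 to compound 4 (0.56 log units; beyond the scatter)). Compound 4 also cannot be told apart from the two-ring compound 3 (a 1.0-fold higher number from compound 3 to compound 4 (0.02 log units; within the scatter)), so a second ring is not what sets the level here. Nothing measured here explains why the single ring does so well.

Still open, going by these compounds, is what a plain phenyl ring would give in place of the pyridine. Also open, on these data alone, is whether the methyl branch of the chain contributes.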